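Cytotoxicity notes: epimer of compound 3 in the lactone series

This account rests on a few compounds, and the source may have more. Where it says the series, first, only, none or still open, it means among the compounds named here.

Measured compounds:
compound 1 `C#CC[C@H]1C[C@H](n2cccc2C(=O)CC)C(=O)O1` — 40700 nM
compound 2 `CC(=O)c1cccn1[C@H]1C[C@@H](Cc2cn(Cc3ccccc3)nn2)OC1=O` — 91600 nM
compound 3 `CC(=O)c1cccn1[C@H]1C[C@@H](Cc2cn([C@H]3C[C@H](n4cc(C)c(=O)[nH]c4=O)O[C@@H]3CO)nn2)OC1=O` — 96200 nM

All three were run in an ADME assay on N2a cells (Mus musculus) for cytotoxicity, read by MTT assay; on this read-out higher numbers stand for weaker inhibition and lower numbers for stronger inhibition. Compound 3 gives the highest number of the three. Compound 2 sits a short distance from it, a gap that lies within the scatter, so no order between compound 3 and compound 2 can be read from these numbers. Compound 1 gives a lower number, and that gap lies beyond the scatter.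

Compound 4 `CC(=O)c1cccn1[C@H]1C[C@H](Cc2cn([C@H]3C[C@H](n4cc(C)c(=O)[nH]c4=O)O[C@@H]3CO)nn2)OC1=O` is the next compound for this assay. It is the epimer of compound 3: the two compounds have the same atoms and bonds and differ only in configuration as drawn: 1 of 5 stereo elements differ; a stereocentre at a saturated ring carbon is drawn S in compound 3 and R in compound 4. For the measured compounds named here, no pair of measured compounds differs by a stereocentre alone, so there is no measured step of this kind to lean on. With the same atoms and bonds retained, the expectation is a step from compound 3 to compound 4 of no size beyond the scatter, in no particular direction: a 1.1-fold lower number from compound 3 to compound 4 (0.03 log units; within the scatter).

On that basis compound 4 is estimated at 90000 nM, with a range from 45000 nM to 180000 nM.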

Compound 4, half-maximal inhibitory concentration: 95800 nM
For compound 4 the middle estimate is 1.1-fold (0.03 log units) below the measured one; measured number inside the range.
By their numbers in this assay, from the lowest: compound 1; then compounds 2, 4 and 3 (each within the scatter of the next).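

In this assay, the change of the stereocentre at a saturated ring carbon from S to R gives a 1.0-fold lower number from compound 3 to compound 4 (0.00 log units; within the scatter). The earlier compounds shown here offered no pair that separated a stereocentre from other changes, and this pair shows that, with the rest of compound 3 retained, the drawn configuration at this carbon leaves no readable mark on this read-out. The reading concerns this one change alone, with nothing entering or leaving: the fact that compounds 3 and 4 differ only in the configuration as drawn.

Still open, as far as these compounds go, is whether the same change of configuration would read the same way on the background of compound 2, which carries a different group on the shared core. Also open, from the compounds shown here alone, is how this assay would respond to a carboxylic acid or an amine in place of the hydroxymethyl group of compound 3.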